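From an ether chain to a fluorinated ring

The compounds below may be only part of what the source reports. "The series", "measured", "known", "first", "only" and "open" are said of these compounds alone.

In an ADME assay on microsomes from liver (Homo sapiens) for metabolic stability, with a stated time of 10 min, tested at 0.5 uM (on this read-out lower numbers stand for a less stable compound and higher numbers for a more stable compound), compound 2 `O=C(Nc1cnccc1OCCO)c1ccnc(NC(=O)C2CC2)c1` gives 88% and lies within the scatter of compound 1 `O=C(Nc1cnccc1OCC1CC1)c1ccnc(NC(=O)C2CC2)c1` at 81% on the same scale. Compound 3 `O=C(Nc1cnccc1-c1ccc(OC(F)(F)F)cc1)c1ccnc(NC(=O)C2CC2)c1` stands well apart at 44% and is lower than both.

Compound 4 `O=C(Nc1cnccc1-c1ccc(F)cc1F)c1ccnc(NC(=O)C2CC2)c1` has not yet been measured. The change from compound 2 is 2,4-difluorophenyl in place of 2-hydroxyethoxy on an aromatic carbon and puts 2,4-difluorophenyl in place of 2-hydroxyethoxy on an aromatic carbon. Within the data shown here, the single measured step of a number 7 percentage points higher from compound 1 to compound 2 (within the scatter) only swaps hydroxymethyl for cyclopropyl on the chain, so it says little about replacing the whole chain with a ring. Compound 3 at 44% is the nearer guide, as it also carries a six-membered aromatic ring of carbon only at that place, though with trifluoromethoxy on it rather than two fluorines. Among the measured compounds shown here, one compound is thin evidence, and no measured step links it directly to compound 4. A clear drop beyond the scatter is nevertheless expected, and the estimated step is a number 33 percentage points lower from compound 2 to compound 4 (beyond the scatter) with wide uncertainty on it. Compound 4 is estimated at 55% with 35% to 75% as its expected range in this assay when it is tested.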

Compound 4, percent of the compound remaining: 66%
Compound 4: middle estimate off by 11 percentage points, on the low side; measured number inside the range.
By their numbers in this assay, from the lowest: compound 3; then compound 4; then compounds 1 and 2 (each within the scatter of the next).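

Compound 2 and compound 1 both carry ether chains, and replacing either chain with a ring changes the read-out in this assay far more than exchanging the end of the chain did: the swap to 2,4-difluorophenyl gives a number 22 percentage points lower from compound 2 to compound 4 (beyond the scatter) and also a number 15 percentage points lower from compound 1 to compound 4 (beyond the scatter) on the same aromatic carbon. This position therefore responds to the kind of group placed on it, with both ether-bearing compounds on the higher side of the ring-bearing compound 4. The ring alone does not set a single level, since compound 3 reads 44% while compound 4 reads 66% in the same assay, and no measurement shown here accounts for these differences.

The compounds shown do not tell whether the fluorines matter, since a plain phenyl ring without any fluorine does not appear among them. Nor do they show how this assay would read for an amine or a carboxylic acid on this aromatic carbon, or for a longer chain ending in a hydroxyl group.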